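The source may report more compounds than this note shows. Statements on the series, on what has been measured and on what is new or still open speak of the compounds shown alone.

In an ADME assay on Huh-7 cells (Homo sapiens) for cytotoxicity, with a stated time of 72 h (a higher number here means that more compound is tolerated, a lower number that less compound is tolerated), compound 1 `CCC(C)CCn1nc(-c2cccs2)c(O)c(C2=NS(=O)(=O)c3cc(NS(C)(=O)=O)ccc3N2)c1=O` gives > 1000 nM as a limit and not as a number. Compound 2 `CS(=O)(=O)Nc1ccc2c(c1)S(=O)(=O)N=C(c1c(O)c(-c3cccs3)nn(CCC3CC3)c1=O)N2` likewise gives > 33000 nM as a limit only. For the measured compounds named here, the one measured step is a step that the two limits leave unreadable from compound 1 to compound 2 and offers no size to carry forward. Compound 3 `CS(=O)(=O)Nc1ccc2c(c1)S(=O)(=O)N=C(c1c(O)c(-c3cccs3)nn(CC3CCC3)c1=O)N2` differs from compound 2 by cyclobutyl in place of cyclopropylmethyl on a saturated chain carbon bound to an aromatic nitrogen with cyclobutyl in place of cyclopropylmethyl on a saturated chain carbon bound to an aromatic nitrogen. No change beyond the usual scatter is therefore expected in this assay for this swap. The estimated step that the limit leaves unreadable from compound 2 to compound 3 is an expectation only. For compound 3 the expected value is 40000 nM (range 15000 nM to 100000 nM).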

Compound 3, half-maximal cytotoxic concentration: > 1000 nM
Compound 3 ended at the assay's limit; the forecaster's own chance of this, stated with the estimate: 75%; the middle value lies beyond the limit too.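

Compound 1, compound 2 and compound 3 all give limits, not numbers, in this assay, so no new step can be read among them. On these data alone, what stays open is the concentration at which each compound becomes cytotoxic, and whether these chain swaps change it.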